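The compounds below may be only part of what the source reports. "The series", "measured", "known", "first", "only" and "open" are said of these compounds alone.

Among the compounds with values here, in a functional assay on LoVo cells (Homo sapiens) for inhibition, read by MTT assay, with a stated time of 48 h (a higher number here means a weaker inhibitor, a lower number a stronger inhibitor), compound 1 (`COc1ccc(N(C)c2nc(C)nc3ccccc23)cc1C(=O)OCC[Se]C#N`) gives 2960 nM, the highest number of the three measured so far and so the weakest inhibitor of the set. Compound 2 (`COc1ccc(N(C)c2nc(C)nc3ccccc23)cc1OCC[Se]C#N`) gives 19 nM, and compound 3 (`COc1ccc(N(C)c2nc(C)nc3ccccc23)cc1C[Se]C#N`) gives 277 nM. Compound 4 (`COc1ccc(N(C)c2nc(C)nc3ccccc23)cc1C(=O)OCCCCCC[Se]C#N`) is still unmeasured. It shares the core of compound 1 and differs only in the side chain: a group of 7 heavy atoms (5 carbon, 1 nitrogen, 1 selenium; no ring) in place of a group of 3 heavy atoms (1 carbon, 1 nitrogen, 1 selenium; no ring), on a saturated chain carbon, two bonds along the chain from an oxygen next to a carbonyl group.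

Within the data shown here, no measured step makes this change. The nearest evidence comes from changes on the aromatic carbon: a 160-fold lower number from compound 1 to compound 2 (2.19 log units; beyond the scatter) and an 11-fold lower number from compound 1 to compound 3 (1.03 log units; beyond the scatter), both large, and a 15-fold higher number from compound 2 to compound 3 (1.16 log units; beyond the scatter), also large. The group on that carbon therefore matters in this assay, and the number has moved in both directions between these compounds. However, compound 4 keeps the carbonyl group of compound 1, which compound 2 and compound 3 lack, so these steps do not transfer directly and give no direction for a change on a saturated chain carbon. Both steps away from compound 1 lead to a lower number, so a moderate move the same way is expected, though a rise remains possible. The estimated step is a 2.5-fold lower number from compound 1 to compound 4 (0.39 log units; beyond the scatter). For compound 4 the expected value is 1200 nM, with an estimated range of 250 nM to 5000 nM.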

Compound 4, half-maximal inhibitory concentration: 1050 nM
Compound 4: middle estimate off by 1.1-fold (0.06 log units), on the high side; the measured number falls inside the stated range.
By their numbers in this assay, from the lowest: compound 2; then compound 3; then compound 4; then compound 1.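

In this assay, the saturated chain carbon two bonds along the chain from an oxygen next to a carbonyl group now has its first measured change: with the carbonyl kept, the group of 7 heavy atoms in place of the group of 3 heavy atoms gives a 2.8-fold lower number from compound 1 to compound 4 (0.45 log units; beyond the scatter). The number therefore responds to a change at this place as well as on the aromatic carbon, and the step is beyond the scatter. At modest size, however, it is smaller than the large steps of a 160-fold lower number from compound 1 to compound 2 (2.19 log units; beyond the scatter) and an 11-fold lower number from compound 1 to compound 3 (1.03 log units; beyond the scatter), which replace the group on the aromatic carbon. No measurement in hand gives a reason for the new step.

With only two chains at this place, the compounds shown give no trend with chain length, and a longer chain, or an amine at the end of the chain, could continue the move, stop it or reverse it. Also open, from the compounds shown here alone, is whether the same lengthening would lower the number in compound 2, which has an oxygen in place of the carbonyl-bearing link.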